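A Small Addition to Compound 1

The source may report more compounds than this note shows. Statements on the series, on what has been measured and on what is new or still open speak of the compounds shown alone.

Measured in a physicochemical assay for lipophilicity, read by HPLC, measured as chromatographic lipophilicity, at pH 7.4; on this read-out higher numbers stand for higher lipophilicity and lower numbers for lower lipophilicity:
- compound 1 `CC(=O)N1CCC(C(=O)N2N=CCC2c2ccccc2)CC1`: 2.5
- compound 2 `Cc1nnc(N2CCC(C(=O)N3N=CC[C@H]3c3ccccc3)CC2)o1`: 3.2
- compound 3 `CC(C)(C)C(=O)N1N=CCC1c1cc[nH]n1`: 2.7

In this assay compound 1 gives 2.5, and compound 3 at 2.7 lies within the usual scatter of it. Compound 2, at 3.2, reads higher than compound 1, and that gap lies beyond the scatter.

Compound 4 `CCC(=O)N1CCC(C(=O)N2N=CCC2c2ccccc2)CC1`, not yet measured, differs from compound 1 in one place: methyl in place of hydrogen on a saturated chain carbon bound to a carbonyl carbon. This puts methyl in place of hydrogen on a saturated chain carbon bound to a carbonyl carbon, so acetyl becomes propanoyl. Among the compounds with values here, no two measured compounds differ in only one place, so this set gives no direct measure of such a change, and the expectation remains a cautious one. An upward a number 0.30 log units higher from compound 1 to compound 4 (within the scatter) is expected, small enough that it may not stand clear of the scatter. Compound 4 is estimated at 2.8, with an expected range of 2.5 to 3.1.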

Compound 4, distribution coefficient: 3.2
Compound 4: middle estimate off by 0.40 log units, on the low side, and the stated range ends below it.
By their numbers in this assay, from the lowest: compounds 1 and 3 (each within the scatter of the next); then compounds 2 and 4 (each within the scatter of the next).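

Replacing hydrogen with methyl on a saturated chain carbon bound to a carbonyl carbon turns acetyl into propanoyl, and in this assay the reading comes out a number 0.70 log units higher from compound 1 to compound 4 (beyond the scatter). This gives the first direct measure of a change in one place in this set, and it shows that a single added methyl at this position can move the number clear of the usual scatter. Nothing at hand explains the size of this step.

The compounds shown leave open whether a longer chain, such as butanoyl, would extend this rise or level it off, and what a hydroxyl group or an amine on the same chain carbon would do to the number. They also leave open whether the same change gives a similar step on a different core.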